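The source may hold more compounds than are shown below. What is called first, only, known or untested is meant among the compounds shown, and "the series" means these compounds.

Measured so far:
- compound 1, `O=C(O)c1cn(C2CC2)c2cc(N3CCCC3)c(F)cc2c1=O`: 38 ug/mL
- compound 2, `CC1(CN)CCN(c2cc3c(cc2F)c(=O)c(C(=O)O)cn3C2CC2)C1`: 23 ug/mL

Both were tested in a functional assay on V79 cells (Cricetulus griseus) for cytotoxicity, read by colony formation; a lower number here means a stronger inhibitor, a higher number a weaker inhibitor. Compound 2 has the lowest of the two numbers, yet the step of a 1.7-fold lower number from compound 1 to compound 2 (0.22 log units; within the scatter) lies within the scatter, so the two are not told apart. Compound 3, `CC1CN(c2cc3c(cc2F)c(=O)c(C(=O)O)cn3C2CC2)CC(C)N1`, has not been measured; it differs from compound 2 in one place: 3,5-dimethylpiperazin-1-yl in place of 3-(aminomethyl)-3-methylpyrrolidin-1-yl on an aromatic carbon. Among the compounds with values here, the only step that bears on this change, a 1.7-fold lower number from compound 1 to compound 2 (0.22 log units; within the scatter), also swapped one saturated ring on that carbon for another and stayed within the scatter, so no step beyond the scatter is expected here. Compound 3 is estimated at 30 ug/mL, between 12 ug/mL and 75 ug/mL, an expected step of a 1.3-fold higher number from compound 2 to compound 3 (0.12 log units; within the scatter).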

Compound 3, half-maximal inhibitory concentration: > 500 ug/mL
Compound 3 gave a limit, no number; the forecaster's own chance of this, stated with the estimate: 5%; middle value at least 16-fold (1.22 log units) away from the limit.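

In this assay the choice of ring on this aromatic carbon turns out to matter: 3,5-dimethylpiperazin-1-yl, a six-membered ring with the same atoms as the five-membered 3-(aminomethyl)-3-methylpyrrolidin-1-yl, gives a large step (an at least 21-fold higher number from compound 2 to compound 3 (1.33 log units; beyond the scatter)). The step from pyrrolidin-1-yl is also large (an at least 13-fold higher number from compound 1 to compound 3 (1.11 log units; beyond the scatter)), whereas the swap between the two five-membered rings stayed within the scatter. Compound 3 gave a limit of the assay, not a number: (the limit of > 500 ug/mL in this assay, at which 1 of the 3 values shown sits).

Still open, as far as these compounds go, is whether the six-membered ring or its two methyl groups go with this step. Plain piperazin-1-yl, without the methyl groups, would separate the two.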